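Swapping One Small Aromatic Ring on the Shared Core

A few compounds are considered here, and "the series" means these few. Any claim that something is new, unique, unknown or untested is made for them only; others in the source may bear on it.

Compound 1 `CCC(C)(C)Cc1c[nH]c(CCc2ccc(-c3csnn3)cc2)n1` and compound 2 `CCC(C)(C)Cc1c[nH]c(CCc2ccc(-n3ncnn3)cc2)n1` share a core and differ only in the five-membered aromatic ring attached to it. In a functional assay on HEK293 cells for agonist activity at Bombesin receptor subtype-3 (Mus musculus), read by luminescence and calcium flux, with a stated time of 10 min (a lower number here means that less compound is needed, a higher number that more compound is needed for the effect), compound 1 gives 109 nM, and compound 2 gives 99 nM. Compound 3 `O=C(O)c1cc(F)c(F)cc1-c1ccc(CCc2nc(CC3CCCCC3)c[nH]2)cc1` differs from both in several places, and in this assay compound 3 gives 96 nM. Among these three numbers compound 2 holds the second highest, but the other two lie within the usual scatter of it, so no order among them can be claimed.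

Compound 4 `CCC(C)(C)Cc1c[nH]c(CCc2ccc(-c3ccns3)cc2)n1` is obtained from compound 2 by a single change: 1,2-thiazol-5-yl in place of 2H-tetrazol-2-yl on an aromatic carbon. Among the compounds with values here, the one measured step that bears on this is the ring swap at the same place, a 1.1-fold lower number from compound 1 to compound 2 (0.04 log units; within the scatter), which stayed within the scatter. On that basis the step of a 1.0-fold higher number from compound 2 to compound 4 (0.00 log units; within the scatter) is expected to show no change beyond the scatter. Compound 4 is therefore estimated at 100 nM in this assay, with a range from 40 nM to 250 nM.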

Compound 4, half-maximal effective concentration: 103 nM
Estimate against measurement, compound 4: 1.0-fold (0.01 log units) below; the range from low to high includes it.
By their numbers in this assay, from the lowest: compounds 3, 2, 4 and 1 (each within the scatter of the next).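

In this assay, putting 1,2-thiazol-5-yl in place of 2H-tetrazol-2-yl gives a 1.0-fold higher number from compound 2 to compound 4 (0.02 log units; within the scatter), and putting it in place of 1,2,3-thiadiazol-4-yl gives a 1.1-fold lower number from compound 1 to compound 4 (0.02 log units; within the scatter). At this place, on an aromatic carbon para to a large group, three different five-membered aromatic rings now stand on the shared core, and the swap from 4 hetero atoms and 4 hydrogen-bond acceptors to 2 of each leaves the number within the scatter. Nothing available explains why these rings read alike.

Going by these compounds, every comparable compound here carries a five-membered aromatic ring at this place, so what an amine, a nitrile or a longer chain would do there remains open. Compound 3 differs from the others in several places and says nothing about this position alone.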